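A few compounds are considered here, and "the series" means these few. Any claim that something is new, unique, unknown or untested is made for them only; others in the source may bear on it.

Measured in an ADME assay on HepG2 cells (Homo sapiens) for cytotoxicity, read by MTT assay, with a stated time of 72 h; on this read-out higher numbers stand for lower toxicity in this test and lower numbers for higher toxicity in this test:
Compound 1 `CC(C)Nc1nc2ccsc2c(=O)[nH]1`: 23900 nM
Compound 2 `CC(C)Nc1nc2c(-c3ccc(F)cc3)csc2c(=O)[nH]1`: > 15600 nM (a limit, not a number)

Compound 2 stands only on a limit: its read-out is the limit of > 15600 nM in this assay, at which 1 of the 2 values shown sits. Compound 3 `CC(C)Nc1nc2c(-c3ccc(Cl)cc3)csc2c(=O)[nH]1` differs from compound 2 by chloro in place of fluoro on an aromatic carbon, in words 4-fluorophenyl to 4-chlorophenyl. Among the measured compounds shown here, the one measured step, a step that the limit leaves unreadable from compound 1 to compound 2, adds the aryl group rather than exchanging its halogen, and its size cannot be read. It therefore gives no measured size or direction for this exchange. For the measured compounds named here, the only number available is compound 1 at 23900 nM, and the estimate stays in that region. No change beyond the usual scatter is expected, and the estimated step is a step that the limit leaves unreadable from compound 2 to compound 3. A report of compound 3 as a limit alone would not be surprising. For compound 3 the expected value is 20000 nM, with an estimated range from 8000 nM to 50000 nM.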

Compound 3, half-maximal cytotoxic concentration: 7100 nM
Estimate against measurement, compound 3: 2.8-fold (0.45 log units) above; the measured number lies below the stated range.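

In this assay, chloro in place of fluoro on an aromatic carbon, para to a large group, gives an at least 2.1-fold lower number from compound 2 to compound 3 (0.34 log units; beyond the scatter), so the halogen at this place changes the read-out towards higher toxicity in this test. Setting 4-chlorophenyl in place of hydrogen on the core of compound 1 gives a 3.4-fold lower number from compound 1 to compound 3 (0.53 log units; beyond the scatter), the first readable effect of an aryl group at this position, since the earlier step to the 4-fluorophenyl group cannot be read. Compound 2 stands only at a limit, so the halogen exchange has a lower bound and no exact size: the limit of > 15600 nM in this assay, at which 1 of the 3 values shown sits.

From the compounds shown here alone, whether the lower number follows chloro alone or would also appear with bromo, methoxy or an amine at the same place stays open. An unsubstituted phenyl group would be needed to separate the effect of the aryl ring from that of its halogen.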